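The source may report more compounds than this note shows. Statements on the series, on what has been measured and on what is new or still open speak of the compounds shown alone.

Compound 1 `CCCCc1c(F)c(N)c2c(=O)cc(-c3ccc(N)c(F)c3)oc2c1F` and compound 2 `Nc1ccc(-c2cc(=O)c3c(N)c(F)c(C(=O)O)c(F)c3o2)cc1F` share one core. In a functional assay on HeLa cells (Homo sapiens) for cytotoxicity, read by neutral red uptake, with a stated time of 3 days (on this read-out higher numbers stand for weaker inhibition and lower numbers for stronger inhibition), compound 1 reaches only the limit of the assay, > 100000 nM. In this assay compound 2 likewise gives only the limit > 100000 nM. The step that the two limits leave unreadable from compound 1 to compound 2 cannot be read because the limit of > 100000 nM in this assay, at which 2 of the 2 values shown sit, holds both values. Compound 2 therefore stands at a limit, not at a number. Compound 3 `CN(C)CCC(=O)OCc1c(F)c(N)c2c(=O)cc(-c3ccc(N)c(F)c3)oc2c1F` differs by (((2-(dimethylamino)ethyl)carbonyl)oxy)methyl in place of carboxy on an aromatic carbon. No readable step bears on this change, so no direction beyond the scatter is foreseen in this assay. Compound 3 is expected near 150000 nM, within 50000 nM to 500000 nM. The expected step that the limit leaves unreadable from compound 2 to compound 3 is estimated to stay within the scatter.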

Compound 3, half-maximal inhibitory concentration: 11000 nM
Beside the measured number, compound 3's estimate is 14-fold (1.13 log units) above it; measured number outside the range, below it.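

Compound 3 gives the first readable result at this aromatic carbon, ortho to two fluoro groups: in this assay, (((2-(dimethylamino)ethyl)carbonyl)oxy)methyl in place of carboxy gives an at least 9.0-fold lower number from compound 2 to compound 3 (0.95 log units; beyond the scatter). Set against the butyl of compound 1, the same chain gives an at least 9.0-fold lower number from compound 1 to compound 3 (0.95 log units; beyond the scatter). The group at this one place can thus bring a value off the limit, where butyl and carboxy both left it there: the limit of > 100000 nM in this assay, at which 2 of the 3 values shown sit.

Going by these compounds, it remains open whether the dimethylamino group, the ester or the whole chain goes with the lower number. An ester without the amine, or an amine joined without the ester, would separate these.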